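The compounds below may be only part of what the source reports. "The series", "measured", "known", "first", "only" and "open" are said of these compounds alone.

Compound 1 `Cc1ccc(Cn2cc(CSc3nc(Nc4ccccc4C)c(C#N)c(-c4ccccc4)n3)nn2)cc1`: in a functional assay on MGC-803 cells (Homo sapiens) for inhibition, read by MTT assay, with a stated time of 72 h (on this read-out lower numbers stand for stronger inhibition and higher numbers for weaker inhibition), compound 1 gives > 64000 nM, which is a limit of the assay rather than a number.
Compound 2 `Cc1ccc(Cn2cc(CSc3nc(Nc4ccccc4F)c(C#N)c(-c4ccccc4)n3)nn2)cc1`: in this assay compound 2 gives 22900 nM.

Compound 2 thus holds the only number shown. Among the compounds with values here, the one other value, that of compound 1, is the limit of > 64000 nM in this assay, at which 1 of the 2 values shown sits. Within the data shown here, the single measured step, an at least 2.7-fold lower number from compound 1 to compound 2 (0.44 log units; beyond the scatter), comes from fluoro in place of methyl on an aromatic carbon. Compound 3 `Cc1ccc(Cn2cc(CSc3nc(Nc4ccccc4Cl)c(C#N)c(-c4ccccc4)n3)nn2)cc1` has not been measured. It differs from compound 2 by chloro in place of fluoro on an aromatic carbon, in words chloro in place of fluoro on an aromatic carbon. No measured step exchanges one halogen for another; the only step shown moves from methyl to fluoro, and its size is known only as a lower bound since compound 1 sits at a limit. The change from fluoro to chloro is a smaller kind of alteration than that, and the step in this assay is expected to stay within the scatter or be at most modest. Compound 3 is estimated at 26000 nM, between 10000 nM and 64000 nM, meaning an expected step of a 1.1-fold higher number from compound 2 to compound 3 (0.06 log units; within the scatter).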

Compound 3, half-maximal inhibitory concentration: 17300 nM
Compound 3: middle estimate off by 1.5-fold (0.18 log units), on the high side; measured number inside the range.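

The exchange of 2-fluorophenyl for 2-chlorophenyl gives a 1.3-fold lower number from compound 2 to compound 3 (0.12 log units; within the scatter), so at this place, on an aromatic carbon ortho to a large group, the two halogens cannot be told apart in this assay. The earlier compounds shown here offered only one halogen against methyl, whereas a second halogen now gives the same kind of result, with chloro in place of methyl giving an at least 3.6-fold lower number from compound 1 to compound 3 (0.56 log units; beyond the scatter), so within these three compounds the separation lies between methyl and either halogen rather than between fluoro and chloro. The true size of that step cannot be read, because compound 1 stands at a limit and not at a number: the limit of > 64000 nM in this assay, at which 1 of the 3 values shown sits.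

The compounds shown leave open whether a bromo or methoxy group at this place, or a plain phenyl with hydrogen there, would fall with the two halogens or with methyl, and whether chloro would behave the same way elsewhere on that ring. They also share the rest of the core, so they say nothing about what an amide or a carboxylic acid in place of the nitrile would do in this assay.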